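Shortening the Ketone Side Chain in a Modulator Series

The compounds below may be only part of what the source reports. "The series", "measured", "known", "first", "only" and "open" are said of these compounds alone.

Of the compounds shown here, three have been measured. Compound 1 `COc1cc(C(=O)O)ccc1OCCCCOc1ccc(C(=O)CC(C)(C)C)c(O)c1C` gives 47 nM in an assay on HEK293 cells for positive allosteric modulation of metabotropic glutamate receptor 2 (Rattus norvegicus), read by thallium flux, with a stated time of 2.5 min; on this read-out higher numbers stand for an effect only at larger amounts of compound and lower numbers for an effect already at smaller amounts. Compound 2 `COc1ccc(C(=O)O)cc1OCCCCOc1ccc(C(=O)CC(C)C)c(O)c1C` gives 155 nM, and compound 3 `Cc1c(OCCCCOc2cccc(C(=O)O)c2)ccc(C(=O)CC(C)C)c1O` gives 222 nM. Among these numbers compound 2 stands second highest: its nearest neighbour is compound 3, reached by a 1.4-fold higher number from compound 2 to compound 3 (0.16 log units; within the scatter), while compound 1 lies further off, though compound 1 and compound 2 differ in more than a single place, so no step links them directly.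

Compound 4 `COc1ccc(C(=O)O)cc1OCCCCOc1ccc(C(=O)C(C)C)c(O)c1C` is the next compound to be measured. It differs from compound 2 by isopropyl in place of isobutyl on a carbonyl carbon. Within the data shown here, none of the measured steps touches this part of the molecule; the only step seen, a 1.4-fold higher number from compound 2 to compound 3 (0.16 log units; within the scatter), concerns the methoxy on the aromatic ring and says nothing about the side chain on the carbonyl. With no direct guide, and a change that removes a small part of the chain, the expectation is for a step of a 1.5-fold higher number from compound 2 to compound 4 (0.17 log units; within the scatter), which stays within the scatter. Compound 4 is therefore estimated at 230 nM, with a range from 90 nM to 650 nM.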

Compound 4, half-maximal effective concentration: 116 nM
Estimate against measurement, compound 4: 2.0-fold (0.30 log units) above; low and high end bracket the measured number.
By their numbers in this assay, from the lowest: compound 1; then compounds 4, 2 and 3 (each within the scatter of the next).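

Going from isobutyl to isopropyl on the carbonyl carbon gives a 1.3-fold lower number from compound 2 to compound 4 (0.13 log units; within the scatter) in this assay. This is the first step shown at this part of the molecule, and it indicates that, for this pair, the chain can lose this much without the reading leaving the usual scatter, so compound 2 and compound 4 cannot be told apart here. Nothing available explains why the two compounds read alike, and no supporting data bear on this result.

Still open, on these data alone, is how a methyl, a cyclopropyl ring or a longer chain would read on the same carbonyl carbon, since two close branched groups say little about the wider range. Also open, as far as these compounds go, is whether the same swap would read alike on the core of compound 3, which lacks the methoxy.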